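The compounds below may be only part of what the source reports. "The series", "measured", "known", "first", "only" and "open" are said of these compounds alone.

Measured so far in a physicochemical assay for solubility, measured as kinetic solubility, at pH 2; a higher number here means a more soluble compound, a lower number a less soluble compound:
Compound 1 `CC(C)[C@H](C[C@H]1CCNC1=O)c1ccc(-c2ccc3cccc(F)c3c2)[nH]c1=O`: 38300 nM
Compound 2 `CCC(CC)(c1nnc[nH]1)c1ccc(-c2ccc3cccc(F)c3c2)[nH]c1=O`: 28500 nM
Compound 3 `CC(C)C(Cc1noc(=O)[nH]1)c1ccc(-c2ccc3cccc(F)c3c2)[nH]c1=O`: 18200 nM

Compound 3 gives 18200 nM. That number lies within the usual scatter of repeated measurements of compound 2, at 28500 nM, whereas compound 1, at 38300 nM, reads higher than compound 3 by a margin just beyond that scatter.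

Compound 4 `CC(C)NC(=O)CC(c1ccc(-c2ccc3cccc(F)c3c2)[nH]c1=O)C(C)C` has not been measured yet. The change from compound 3 to compound 4 is a group of 6 heavy atoms (4 carbon, 1 nitrogen, 1 oxygen; no ring) in place of a group of 6 heavy atoms (2 carbon, 2 nitrogen, 2 oxygen; one five-membered aromatic ring with 3 hetero atoms), on a saturated chain carbon, two bonds along the chain from an aromatic carbon: isopropylcarbamoyl, with no ring, enters on a saturated chain carbon, two bonds along the chain from an aromatic carbon.

For the measured compounds named here, no two measured compounds differ in one place only, so no measured step guides this swap directly. Going by the values given here, the only guide is that compound 3, at 18200 nM, and compound 2, at 28500 nM, carry different groups yet stay within the scatter of each other. In this assay the expected change is small, an estimated 1.1-fold higher number from compound 3 to compound 4 (0.04 log units; within the scatter), and not beyond the scatter. The estimate for compound 4 is 20000 nM, with an expected range from 8000 nM to 45000 nM.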

Compound 4, solubility: 24200 nM
Estimate against measurement, compound 4: 1.2-fold (0.08 log units) below; measured number inside the range.
By their numbers in this assay, from the lowest: compounds 3, 4, 2 and 1 (each within the scatter of the next, the first and the last beyond it).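

Swapping the five-membered aromatic ring for isopropylcarbamoyl, on a saturated chain carbon, two bonds along the chain from an aromatic carbon, gives a 1.3-fold higher number from compound 3 to compound 4 (0.12 log units; within the scatter) in this assay and so stays within the usual scatter. For the compounds shown here, this is the first comparison in the set in which two compounds differ in one place only, and at this position the ringed group and the open-chain group, with the same number of heavy atoms, cannot be told apart by this read-out. No measurement in hand offers a reason for this result.

From the compounds shown here alone, whether an amine or a carboxylic acid at this same position would also stay within the scatter remains open. So does the outcome for a longer chain in place of the isopropyl on the amide nitrogen.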